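Difluorocyclopropyl amide and its expected solubility

The source may hold more compounds than are shown below. What is called first, only, known or untested is meant among the compounds shown, and "the series" means these compounds.

Compound 1 `O=C(CC1CCOCC1)Nc1ccc(C2CCCCC2)cc1` gives < 1000 nM in a physicochemical assay for solubility, measured as kinetic solubility (on this read-out higher numbers stand for higher solubility and lower numbers for lower solubility), which is a limit.
Compound 2 `O=C(COCC(F)F)Nc1ccc(C2CCCCC2)cc1` gives < 1000 nM in this assay, which is a limit.

Compound 2 therefore stands only at a limit in this assay, and the step that the two limits leave unreadable from compound 1 to compound 2 cannot be read, as the limit of < 1000 nM in this assay, at which 2 of the 2 values shown sit, shows. Compound 3 `O=C(Nc1ccc(C2CCCCC2)cc1)[C@H]1CC1(F)F` differs from compound 2 by 2,2-difluorocyclopropyl in place of (2,2-difluoroethoxy)methyl on a carbonyl carbon. Among the compounds with values here, no measured step bears readably on this change. For compound 3 the expected step is a step that the limit leaves unreadable from compound 2 to compound 3, nothing beyond the scatter. Compound 3 is estimated at 500 nM, between 100 nM and 2000 nM, most likely reported again as a limit.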

Compound 3, solubility: < 1000 nM
Compound 3 ended at the assay's limit; the forecaster's own chance of this, stated with the estimate: 75%; the middle value lies beyond the limit too.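

No new step can be read among compound 1, compound 2 and compound 3 in this assay, because all three stand at one limit: the limit of < 1000 nM in this assay, at which 3 of the 3 values shown sit.

The compounds shown leave open how far each lies from that limit, and whether exchanging these groups on the carbonyl carbon changes the read-out of this assay at all.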